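Fluoro to Chloro Exchange Across Two Cores

This account rests on a few compounds, and the source may have more. Where it says the series, first, only, none or still open, it means among the compounds named here.

Measured in a functional assay on B16-F10 cells (Mus musculus) for antiproliferative activity, read by ELISA and MTT assay, with a stated time of 48 h; a higher number here means a weaker inhibitor, a lower number a stronger inhibitor:
Compound 1, `Cc1ccc(S(=O)(=O)NC(=O)/C=C/c2ccc(F)cc2)cc1` — 4.8 ug/mL
Compound 2, `Cc1ccc(S(=O)(=O)NC(=O)/C=C/c2ccc(Cl)cc2)cc1` — 4.6 ug/mL
Compound 3, `O=C(/C=C/c1ccc([N+](=O)[O-])cc1)NS(=O)(=O)c1ccc(F)cc1` — 2.2 ug/mL

Compound 1 and compound 2 share one core and differ by chloro in place of fluoro on an aromatic carbon. The step of a 1.0-fold lower number from compound 1 to compound 2 (0.02 log units; within the scatter) is within the scatter, so the two values show no change that can be read as real.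

Compound 3 carries a different core; how it differs from compound 1 is not broken down here. In this assay compound 3 gives the lowest of the three numbers, and its steps to compound 2 and to compound 1 are both beyond the scatter, so compound 3 counts as the strongest inhibitor among the measured three.

Compound 4, `O=C(/C=C/c1ccc([N+](=O)[O-])cc1)NS(=O)(=O)c1ccc(Cl)cc1`, is not yet measured. It differs from compound 3 by chloro in place of fluoro on an aromatic carbon, the same change that separates compound 1 from compound 2: the place is the same word for word in both pairs, so this is the same change, only on the core of compound 3 instead of that of compound 1.

The step from compound 3 to compound 4 is expected to be no change at the digits printed from compound 3 to compound 4 (within the scatter), resting on compound 1 and compound 2, where the same exchange gave a 1.0-fold lower number from compound 1 to compound 2 (0.02 log units; within the scatter). Compound 4 is therefore estimated at 2.2 ug/mL, between 1.2 ug/mL and 4.2 ug/mL, a range that is set by the usual scatter rather than by any expected shift.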

Compound 4, half-maximal inhibitory concentration: 13.7 ug/mL
The estimate for compound 4 lay 6.2-fold (0.79 log units) below the measured number; the whole stated range lies below it.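

In this assay the exchange of fluoro for chloro does not carry over unchanged from one core to the other: on the core of compound 3 it gives a 6.2-fold higher number from compound 3 to compound 4 (0.79 log units; beyond the scatter), and set beside the earlier pair the two steps disagree: the same change on two cores in this assay, a 1.0-fold lower number (0.02 log units; within the scatter) from compound 1 to compound 2 and a 6.2-fold higher number (0.79 log units; beyond the scatter) from compound 3 to compound 4, 6.5-fold (0.81 log units) apart, beyond the scatter of two such steps

A silent exchange on the core of compound 1 is therefore no guide to the same exchange on the core of compound 3, and in this series the effect of this change has to be read core by core. For the compounds shown here, the result does not show what separates the two outcomes, since the two cores differ in more than one place, and with only two pairs, both in one assay, it gives no rule for any further core.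

Open, going by these compounds, is whether the step on the core of compound 3 is specific to chloro or would also appear with another halogen, such as bromo, in the same place. Also open, on these data alone, is whether it survives when the nitro group of compound 3 and compound 4 gives way to an amine or a carboxylic acid, which would show how much of the disagreement follows that group.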